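This account rests on a few compounds, and the source may have more. Where it says the series, first, only, none or still open, it means among the compounds named here.

Compound 1 `COc1cc(C(=O)/C=C/c2ccc3c(c2)B(O)OC3)cc(OC)c1OC`: > 10 ug/mL
Compound 2 `O=C(/C=C/c1ccc2c(c1)B(O)OC2)c1ccc(C(F)(F)F)cc1`: > 10 ug/mL
Compound 3 `Cn1cccc1C(=O)/C=C/c1ccc2c(c1)B(O)OC2`: > 10 ug/mL

All three compounds were tested in an ADME assay on L929 cells (Mus musculus) for cytotoxicity, read by resazurin assay, with a stated time of 72 h; on this read-out lower numbers stand for stronger inhibition and higher numbers for weaker inhibition. In this assay compound 1 gives > 10 ug/mL, which is a limit of the assay and not a number. It has no exact place in a ranking, and the other two compounds share its position: the limit of > 10 ug/mL in this assay, at which 3 of the 3 values shown sit.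

Compound 4 `COc1ccc(C(=O)/C=C/c2ccc3c(c2)B(O)OC3)cc1OC` keeps the shared core of compound 1 and differs in one place: hydrogen in place of methoxy on an aromatic carbon. A methoxy group leaves, and hydrogen takes its place on an aromatic carbon.

Going by the values given here, no two measured compounds differ in just one place, so no measured step speaks directly to this swap. The nearest guide is how little the readings differ across the set. Compound 2 carries a trifluoromethyl group on its aromatic ring, and it gives > 10 ug/mL, also a limit. Compound 3 carries a different ring again, and it gives > 10 ug/mL, once more a limit.

Losing one methoxy group is therefore expected to cause no step beyond the usual scatter in this assay, and no clear direction is expected. The estimated step is a step that the limit leaves unreadable from compound 1 to compound 4. For compound 4 the expected value is 15 ug/mL, within an estimated range of 6 ug/mL to 40 ug/mL.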

Compound 4, half-maximal inhibitory concentration: > 10 ug/mL
Compound 4 ended at the assay's limit; the forecaster's own chance of this, stated with the estimate: 80%; the middle value lies beyond the limit too.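

In this assay compound 4 gives > 10 ug/mL, which is a limit of the assay and not a number. Compound 1 also stands at a limit, so no step between compound 1 and compound 4 can be read: the limit of > 10 ug/mL in this assay, at which 4 of the 4 values shown sit.

The compounds shown leave open how much cytotoxicity any of them has, and whether any change to the shared core would give an exact reading.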